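Methoxy in Place of Hydrogen on the Core of Compound 2

The compounds below may be only part of what the source reports. "The series", "measured", "known", "first", "only" and "open" are said of these compounds alone.

Three close relatives of one shared core have been tested in a functional assay on MDA-MB-231 cells (Homo sapiens) for inhibition, read by CCK-8 assay, with a stated time of 72 h, tested at 20 uM; a higher number here means more inhibition of growth at the concentration tested, a lower number less inhibition of growth. Compound 1 `CCOC(=O)/C=C1/C(=O)Nc2ccccc21` gives 86.9%, compound 2 `CC(C)(C)OC(=O)/C=C1/C(=O)Nc2ccccc21` gives 87.6%, and compound 3 `Cc1ccc2c(c1)/C(=C\C(=O)OC(C)(C)C)C(=O)N2` gives 87.8%. Compound 2 thus sits with the other two within the scatter: a number 0.7 percentage points higher from compound 1 to compound 2 (within the scatter) and a number 0.2 percentage points higher from compound 2 to compound 3 (within the scatter) both fall inside it. Compound 4 `COc1cccc2c1NC(=O)/C2=C/C(=O)OC(C)(C)C` differs from compound 2 by methoxy in place of hydrogen on an aromatic carbon. Going by the values given here, the only measured step that bears on a change at an aromatic carbon is a number 0.2 percentage points higher from compound 2 to compound 3 (within the scatter), and it stayed within the scatter, though there a methyl rather than a methoxy entered. Therefore no step beyond the scatter is expected here, a number 0.6 percentage points lower from compound 2 to compound 4 (within the scatter). Compound 4 is estimated at 87%, within 79% to 94%.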

Compound 4, percent growth inhibition at one concentration: 86.7%
Compound 4: middle estimate off by 0.3 percentage points, on the high side; low and high end bracket the measured number.
By their numbers in this assay, from the lowest: compounds 4, 1, 2 and 3 (each within the scatter of the next).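

Adding a methoxy group to the core, at a carbon ortho to a fused ring and meta to a fused ring, gives in this assay a number 0.9 percentage points lower from compound 2 to compound 4 (within the scatter). Before this, only a methyl had entered on an aromatic carbon of the shared core; methoxy, which brings a hydrogen-bond acceptor, is a second such change that stays within the scatter. Nothing shown here offers an explanation for this result. Going by these compounds, whether an amine or a carboxylic acid on this carbon would also stay within the scatter remains open, as does methoxy on the ring's other aromatic carbons.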